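Swapping the Aryl Group on the Ring Nitrogen

The source may report more compounds than this note shows. Statements on the series, on what has been measured and on what is new or still open speak of the compounds shown alone.

Of the compounds shown here, two sharing one core have been measured. Compound 1 `O=C(Nc1cc(-c2ccccc2)nn1-c1ccccc1)c1cccc(C(F)(F)F)c1` gives 228 nM in a functional assay on cells for positive allosteric modulation of metabotropic glutamate receptor 5 (Rattus norvegicus), read by calcium flux; a higher number here means that more compound is needed for the effect, a lower number that less compound is needed. Compound 2 `O=C(Nc1cc(-c2ccccc2)nn1-c1ccccc1F)c1ccccc1` gives 104 nM in this assay, the lowest of the two numbers, and the gap to compound 1 lies beyond the usual scatter of repeated measurements. Compound 3 `COc1cccc(-n2nc(-c3ccccc3)cc2NC(=O)c2ccccc2)c1` has not yet been measured. It differs from compound 2 in one place: 3-methoxyphenyl in place of 2-fluorophenyl on an aromatic nitrogen. Among the measured compounds shown here, no measured pair shows a change of this kind, so the data at hand give no direct guide to its effect. The step is expected to move this assay upward by a modest amount, a 1.9-fold higher number from compound 2 to compound 3 (0.28 log units; within the scatter), though a result within the scatter of compound 2 would not be surprising. Compound 3 is therefore estimated at 200 nM, with a likely range from 70 nM to 600 nM.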

Compound 3, half-maximal effective concentration: 570 nM
Beside the measured number, compound 3's estimate is 2.9-fold (0.45 log units) below it; low and high end bracket the measured number.
By their numbers in this assay, from the lowest: compound 2; then compound 1; then compound 3.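

With the benzamido group and the phenyl group on the shared core held fixed, 3-methoxyphenyl in place of 2-fluorophenyl on the aromatic nitrogen gives a 5.5-fold higher number from compound 2 to compound 3 (0.74 log units; beyond the scatter) in this assay and so lies beyond the usual scatter. Among the compounds shown here, this is the first change confined to this position, and it shows that the number read in this assay responds to which aryl group sits on that nitrogen. No measured information at hand accounts for the size or direction of this step.

The step replaces the fluorine with a methoxy group and also moves the substituent around the phenyl ring, so the compounds shown cannot separate these two changes. They also leave open how this position would respond to a phenyl ring carrying an amine or a carboxylic acid, or to a longer chain in place of the aryl group.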